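From Bromo to Iodo on KB Cells

This account rests on a few compounds, and the source may have more. Where it says the series, first, only, none or still open, it means among the compounds named here.

Compound 1, `Cc1cccc(NC(=O)C(Cl)Cl)c1`: "not determined" (no result reported)
Compound 2, `O=C(Nc1cccc(Cl)c1)C(Cl)Cl`: "not determined" (no result reported)
Compound 3, `O=C(Nc1cccc(Br)c1)C(Cl)Cl`: 8180 nM
Compound 4, `O=C(Nc1cccc(I)c1)C(Cl)Cl`: not yet measured

In a functional assay on KB cells (Homo sapiens) for antiproliferative activity, read by MTT assay, with a stated time of 72 h (a higher number here means a weaker inhibitor, a lower number a stronger inhibitor), compound 3 gives 8180 nM, and it stands alone, since compound 1 gives "not determined" (no result reported) and compound 2 gives "not determined" (no result reported) in this assay. Compound 4 differs from compound 3 in one place: iodo in place of bromo on an aromatic carbon. Among the measured compounds shown here, no step between two measured compounds is available to guide this change, so the expectation rests on the single value of compound 3 and on the small size of the change. The step from compound 3 to compound 4 is expected to be a 1.3-fold lower number from compound 3 to compound 4 (0.10 log units; within the scatter), that is, no change beyond the usual scatter in either direction. Compound 4 is therefore estimated to give 6500 nM in this assay, with a range from 2500 nM to 16000 nM.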

Compound 4, half-maximal inhibitory concentration: 5250 nM
The estimate for compound 4 lay 1.2-fold (0.09 log units) above the measured number, within the range that was stated.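

In this assay, among the compounds shown here, replacing bromo with iodo on this aromatic carbon gives a 1.6-fold lower number from compound 3 to compound 4 (0.19 log units; within the scatter) and so provides the first step at this position. Iodo and bromo cannot be told apart here, so this exchange leaves the reading at this place unchanged within the scatter. No measurement available here bears on the reason for this result.

Going by these compounds, whether an amine, a carboxylic acid or a longer chain at this position would move the number beyond the scatter stays open. So does the outcome of replacing the two chlorines of the acyl part with other atoms.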